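The compounds below may be only part of what the source reports. "The series", "measured", "known", "first", "only" and "open" are said of these compounds alone.

Compound 1 `CN1C(=O)C(C)(C)C[C@H]1C(=O)NCc1cccc(C(F)(F)F)c1Cl` gives < 0.5 mL.min-1.g-1 in an in vitro ADME assay on microsomes from liver (Rattus norvegicus) for metabolic stability (on this read-out lower numbers stand for slow clearance and higher numbers for fast clearance), and this is a limit of the assay, not a number. Two compounds give actual numbers in this assay: compound 2 `CN1C(=O)C(F)(F)C[C@H]1C(=O)NCc1cccc(C(F)(F)F)c1Cl` gives 0.7 mL.min-1.g-1 and compound 3 `CN1CCC(N2C[C@@H](C(=O)NCc3cccc(C(F)(F)F)c3Cl)N(C)C2=O)CC1` gives 0.5 mL.min-1.g-1, so compound 3 stands within the scatter of compound 2. Compound 4 `Cc1ncccc1N1C[C@@H](C(=O)NCc2cccc(C(F)(F)F)c2Cl)N(C)C1=O` carries 2-methylpyridin-3-yl in place of 1-methylpiperidin-4-yl on an amide-type nitrogen in a ring. For the measured compounds named here, no measured pair in this small set tests such an exchange, so the expectation rests on compound 3 at 0.5 mL.min-1.g-1, with no step beyond the scatter expected in this assay. The expected step is a 1.4-fold higher number from compound 3 to compound 4 (0.15 log units; within the scatter). Compound 4 is estimated at 0.7 mL.min-1.g-1, with an expected range from 0.4 mL.min-1.g-1 to 1.5 mL.min-1.g-1.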

Compound 4, intrinsic clearance in microsomes: 2.6 mL.min-1.g-1
Compound 4: middle estimate off by 3.7-fold (0.57 log units), on the low side, outside the stated range (above it).
By their numbers in this assay, from the lowest: compounds 3 and 2 (each within the scatter of the next); then compound 4.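

At this place on the amide-type nitrogen, the exchange is not neutral in this assay: 2-methylpyridin-3-yl in place of 1-methylpiperidin-4-yl gives a 5.2-fold higher number from compound 3 to compound 4 (0.72 log units; beyond the scatter). For the compounds shown here, the step is the first one read in this set, and it comes with an aromatic ring replacing a non-aromatic one, with heavy atoms, donors and acceptors unchanged in number. It runs between two actual numbers, and only compound 1 sits at a limit of the assay: the limit of < 0.5 mL.min-1.g-1 in this assay, at which 1 of the 4 values shown sits.

The compounds shown leave open whether the rise belongs to the aromatic ring or to its methyl group. A pyridin-3-yl without the methyl, or a plain phenyl, at this place would speak to that.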